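A few compounds are considered here, and "the series" means these few. Any claim that something is new, unique, unknown or untested is made for them only; others in the source may bear on it.

Compound 2 `CC(C)(C)c1cc(OC(=O)c2ccc(Cl)cc2)ccc1O` stands at the assay ceiling: in an assay on isolated protein for antagonist activity at Bile acid receptor (Homo sapiens), read by HTRF, with a stated time of 30 min (on this read-out higher numbers stand for weaker inhibition and lower numbers for stronger inhibition), compound 2 gives > 100000 nM, a limit rather than a number. Compound 1 `Cc1ccc(C(=O)Oc2ccc(O)c(C(C)(C)C)c2)cc1` gives > 100000 nM in this assay, likewise a limit. The step that the two limits leave unreadable from compound 1 to compound 2 is therefore not readable, as shown by the limit of > 100000 nM in this assay, at which 2 of the 2 values shown sit. Compound 3 `CC(C)(C)c1cc(OC(=O)c2ccccc2)ccc1O` differs from compound 2 by hydrogen in place of chloro on an aromatic carbon. Among the measured compounds shown here, the single measured step, chloro for methyl, gave no readable size, so neither size nor direction can be drawn from it for the present change. Compound 3 is therefore expected to remain at the limit, with an estimated value of 150000 nM and a range from 30000 nM to 1000000 nM. The expected step that the limit leaves unreadable from compound 2 to compound 3 is thus essentially none.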

Compound 3, half-maximal inhibitory concentration: > 100000 nM
Compound 3 ended at the assay's limit; the forecaster's own chance of this, stated with the estimate: 85%; the middle value does not contradict the limit.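

The steps among compound 1, compound 2 and compound 3 cannot be read, because each value is a limit and not a number: the limit of > 100000 nM in this assay, at which 3 of the 3 values shown sit.

The compounds shown leave open whether any change to the shared core gives a measurable inhibition.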